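The source may report more compounds than this note shows. Statements on the series, on what has been measured and on what is new or still open speak of the compounds shown alone.

Compound 1, `COc1ccc(-c2ccc(COCCCCCN3C[C@H](O)[C@@H](O)[C@H](O)[C@H]3CO)cc2)cc1`, gives 10 nM in an assay on isolated protein for inhibition of Beta-glucosidase (Homo sapiens); on this read-out higher numbers stand for weaker inhibition and lower numbers for stronger inhibition.
Compound 2, `N#Cc1ccc(-c2ccc(COCCCCCN3C[C@H](O)[C@@H](O)[C@H](O)[C@H]3CO)cc2)cc1`, gives 3 nM in this assay.

Of these two numbers, compound 2 holds the lower one; the step of a 3.3-fold lower number from compound 1 to compound 2 (0.52 log units; beyond the scatter) lies beyond the scatter and is modest in size. Compound 3, `OC[C@@H]1[C@@H](O)[C@H](O)[C@@H](O)CN1CCCCCOCc1ccc(-c2ccc(F)nc2)cc1`, differs from compound 2 in that (6-fluoropyridin-3-yl in place of 4-cyanophenyl on an aromatic carbon). Within the data shown here, no measured step exchanges one aromatic ring for another, so the single step from compound 1 to compound 2 bears on it only loosely. Compound 3 is therefore expected to stay close to compound 2, with the step of a 1.7-fold higher number from compound 2 to compound 3 (0.22 log units; within the scatter) expected to remain within the scatter. Compound 3 is estimated at 5 nM, within 1.5 nM to 15 nM.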

Compound 3, half-maximal inhibitory concentration: 5 nM
Compound 3: the middle estimate sits on the measured number at the digits printed; the range from low to high includes it.
By their numbers in this assay, from the lowest: compounds 2, 3 and 1 (each within the scatter of the next, the first and the last beyond it).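

In this assay the exchange of rings gives a 1.7-fold higher number from compound 2 to compound 3 (0.22 log units; within the scatter) and so a 6-fluoropyridin-3-yl group, an aromatic ring with a hetero atom, does as well at this place as 4-cyanophenyl. Against 4-methoxyphenyl the same group gives a 2.0-fold lower number from compound 1 to compound 3 (0.30 log units; within the scatter) so compound 3 cannot be separated from either of the others, although compound 1 and compound 2 stand apart beyond the scatter. Nothing at hand explains these numbers. Still open, from the compounds shown here alone, is how an amine or a carboxylic acid at this place would fare, and what the fluorine contributes on its own.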